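Trifluoromethyl in place of methyl on a shared core

A few compounds are considered here, and "the series" means these few. Any claim that something is new, unique, unknown or untested is made for them only; others in the source may bear on it.

Compound 1 `C/N=C(/S)C1=CC(C)(C)Oc2ccc([N+](=O)[O-])cc21` is tested in a functional assay (aorta) with Rattus norvegicus as the target (on this read-out higher numbers stand for an effect only at larger amounts of compound and lower numbers for an effect already at smaller amounts), where compound 1 gives 1.35 nM. Compound 2 `C/N=C(/S)C1=CC(C)(C(F)(F)F)Oc2ccc([N+](=O)[O-])cc21` differs from it by trifluoromethyl in place of methyl on a saturated ring carbon; in this assay compound 2 gives 0.302 nM, and the step is a 4.5-fold lower number from compound 1 to compound 2 (0.65 log units; beyond the scatter). Compound 3 `CC1(C(F)(F)F)C=C(C(=O)NCCC#N)c2cc([N+](=O)[O-])ccc2O1` carries a larger group on the double-bonded ring carbon; in this assay compound 3 gives 0.692 nM, a step of a 2.3-fold higher number from compound 2 to compound 3 (0.36 log units; beyond the scatter). The difference between the core of compound 1 and the core of compound 3 is not broken down here. Compound 4 `N#CCCNC(=O)C1=CC(C(F)(F)F)(C(F)(F)F)Oc2ccc([N+](=O)[O-])cc21` differs from compound 3 by trifluoromethyl in place of methyl on a saturated ring carbon. This is the same kind of change as that between compound 1 and compound 2, but here the ring atom two ring bonds away bears a (2-cyanoethyl)carbamoyl group (7 heavy atoms) rather than a group of 4 heavy atoms. For compound 4 a step of similar size is expected, a 4.3-fold lower number from compound 3 to compound 4 (0.64 log units; beyond the scatter), because the earlier step of a 4.5-fold lower number from compound 1 to compound 2 (0.65 log units; beyond the scatter) went beyond the scatter. Compound 4 is therefore estimated at 0.16 nM, likely between 0.06 nM and 0.45 nM.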

Compound 4, half-maximal effective concentration: 0.49 nM
Estimate against measurement, compound 4: 3.1-fold (0.49 log units) below; the measured number lies above the stated range.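

In this assay, trifluoromethyl in place of methyl gives a 1.4-fold lower number from compound 3 to compound 4 (0.15 log units; within the scatter), so on this core the change has no clear effect. The size of the step did not carry over from one core to the other: the same change on two cores in this assay, a 4.5-fold lower number (0.65 log units; beyond the scatter) from compound 1 to compound 2 and a 1.4-fold lower number (0.15 log units; within the scatter) from compound 3 to compound 4, 3.2-fold (0.50 log units) apart, beyond the scatter of two such steps. Among the compounds shown here, with only two pairs, this shows that the step cannot simply be assumed to transfer, but it does not show which feature of the two cores sets its size or what a third core would give.

As far as these compounds go, it remains open whether the step would stay small if a longer chain or a chain ending in a carboxylic acid replaced the (2-cyanoethyl)carbamoyl group. From the compounds shown here alone, it is also open how ethyl would compare with methyl and trifluoromethyl on the saturated ring carbon.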